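Cytotoxicity notes: carbonyl ring change from compound 3 to compound 4

The source may report more compounds than this note shows. Statements on the series, on what has been measured and on what is new or still open speak of the compounds shown alone.

The shared core, seen in compound 1 `O=C(NC(=S)N1CCc2c(OCCCCCOc3ccc(Cl)cc3)cccc21)c1ccc(Br)cc1`, carries a varied ring on the carbonyl carbon. In an ADME assay on Huh-7 cells (Homo sapiens) for cytotoxicity (a higher number here means that more compound is tolerated, a lower number that less compound is tolerated), compound 1 gives 29100 nM. Compound 2 `COc1ccc(C(=O)NC(=S)N2CCc3c(OCCCCCOc4ccc(Cl)cc4)cccc32)cc1` gives 34400 nM in this assay. Compound 3 `CC(C)(C)c1ccc(C(=O)NC(=S)N2CCc3c(OCCCCCOc4ccc(Cl)cc4)cccc32)cc1` reports only a limit in this assay, > 50000 nM. The steps among these, a 1.2-fold higher number from compound 1 to compound 2 (0.07 log units; within the scatter), an at least 1.7-fold higher number from compound 1 to compound 3 (0.23 log units; that floor lies within the scatter) and an at least 1.4-fold higher number from compound 2 to compound 3 (0.16 log units; that floor lies within the scatter), all stay within the scatter; compound 3 sits at the limit (the limit of > 50000 nM in this assay, at which 1 of the 3 values shown sits), so only a floor is known for it.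

Compound 4 `O=C(NC(=S)N1CCc2c(OCCCCCOc3ccc(Cl)cc3)cccc21)c1ccsc1` differs from compound 3 by thiophen-3-yl in place of 4-(tert-butyl)phenyl on a carbonyl carbon. The measured steps exchange one group on an aromatic carbon of the same six-membered aromatic ring, and none moves the value beyond the scatter. Among the compounds with values here, the present change exchanges the whole ring, for which no measured step exists, so the expectation rests on the flat behaviour so far: no step beyond the scatter is expected, an at least 1.2-fold lower number from compound 3 to compound 4 (0.09 log units; that floor lies within the scatter). Compound 4 is therefore estimated at 40000 nM, between 15000 nM and 110000 nM, with a fair chance that this assay again reports only a limit.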

Compound 4, half-maximal cytotoxic concentration: > 50000 nM
Compound 4: no number, only a limit; the forecaster's own chance of this, stated with the estimate: 45%; at least 1.2-fold (0.09 log units) between middle value and limit.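

Compound 4 gives only a limit in this assay, so a five-membered aromatic ring with 1 hetero atom on this carbonyl carbon reaches the same ceiling as compound 3, which carries a six-membered aromatic ring of carbon only: the limit of > 50000 nM in this assay, at which 2 of the 4 values shown sit.

Against the compounds with numbers, the result reads as an at least 1.4-fold higher number from compound 2 to compound 4 (0.16 log units; that floor lies within the scatter) and an at least 1.7-fold higher number from compound 1 to compound 4 (0.23 log units; that floor lies within the scatter), so exchanging the whole ring shows no step beyond the scatter, though the true size of both steps stays unknown. The step between compound 3 and compound 4 cannot be read, as both values are limits.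

The compounds shown leave open where the true values of compound 3 and compound 4 lie, and whether any group on this carbonyl carbon moves the value beyond the scatter. An amine or a carboxylic acid on the ring, or an alkyl chain in place of the ring, would test this.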